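The compounds below may be only part of what the source reports. "The series", "measured", "known", "first", "only" and "open" are said of these compounds alone.

Measured so far:
compound 1 `COc1cccc(-c2nc(C(F)(F)F)n(CC[C@@H](O)C[C@@H](O)CC(=O)O)c2-c2ccc(F)cc2)c1` — 20 nM
compound 2 `O=C(O)C[C@H](O)C[C@H](O)CCn1c(C(F)(F)F)nc(-c2ccc(F)cc2)c1-c1ccccc1` — 201 nM

Compound 2 holds the higher of the two numbers in an assay on microsomes from liver for inhibition of 3-hydroxy-3-methylglutaryl-coenzyme A reductase (Rattus norvegicus); on this read-out lower numbers stand for stronger inhibition and higher numbers for weaker inhibition; compound 1 gives 20 nM against compound 2 at 201 nM, a gap beyond the scatter.

Compound 3 `Cc1ccc(-c2c(-c3ccc(F)cc3)nc(C(F)(F)F)n2CC[C@@H](O)C[C@@H](O)CC(=O)O)cc1` differs from compound 2 by methyl in place of hydrogen on an aromatic carbon. Among the measured compounds shown here, no measured pair shows this change. Compound 1 and compound 2 only show that a substituted ring here can sit at a lower number. For compound 3 a modest step toward a lower number is expected, a 1.7-fold lower number from compound 2 to compound 3 (0.22 log units; within the scatter). Compound 3 is estimated at 120 nM, range 40 nM to 400 nM.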

Compound 3, half-maximal inhibitory concentration: 750 nM
Beside the measured number, compound 3's estimate is 6.3-fold (0.80 log units) below it; the measured number lies above the stated range.
By their numbers in this assay, from the lowest: compound 1; then compound 2; then compound 3.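

In this assay, among the compounds shown here, the change from phenyl to 4-methylphenyl gives the first step that differs in one place, a 3.7-fold higher number from compound 2 to compound 3 (0.57 log units; beyond the scatter), and it weakens inhibition. A single methyl para to a large group is therefore enough to shift the number at this position, and the ring does not accept this substituent without cost. No measurement at hand gives a reason for the step.

From the compounds shown here alone, it remains open whether a chlorine, a hydroxyl or a methoxy group at the same place would shift the number as methyl does. Going by these compounds, an ethyl group at this place is equally open.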